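A few compounds are considered here, and "the series" means these few. Any claim that something is new, unique, unknown or untested is made for them only; others in the source may bear on it.

Compound 1 `CCc1cccc(NC(=O)CN2CCN(c3ccc(Cl)cn3)CC2)c1`, compound 2 `Cc1cccc(NC(=O)CN2CCN(c3ncccn3)CC2)c1` and compound 3 `O=C(CN1CCN(c2ccc(Cl)cn2)CC1)Nc1cncnc1` share one core. In an assay on cells for agonist activity at D(4) dopamine receptor (Homo sapiens), read by luminescence and beta-arrestin recruitment, with a stated time of 90 min (a lower number here means a smaller maximal response, a higher number a larger maximal response), compound 2 gives 24.7%. Compound 1 is reported as "not active" (no number reported), without a number. In this assay compound 3 likewise stands at "not active" (no number reported), so no figure places it; it shares this outcome with compound 1, and compound 2 alone carries a value. Compound 4 `Cc1cccc(NC(=O)CN2CCN(c3ccc(Cl)cn3)CC2)c1` has not yet been measured. Compound 4 differs from compound 3 in one place: 3-methylphenyl in place of pyrimidin-5-yl on an amide-type nitrogen. Among the compounds with values here, no measured pair shows this exact change, so its size in this assay is uncertain; a modest rise is expected, since compound 2 bearing the same 3-methylphenyl group gives 24.7%. Compound 4 is therefore expected to reach about 20% in this assay, within 0% to 45%, with a real chance that no number is reported.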

Compound 4, largest response reached (Emax), in percent of the reference or control that the assay uses: "not active" (no number reported)
For compound 4 the study gives words and no number; the estimate stays without a comparison.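

In this assay compound 3 and compound 4 both stand without a number, so no step can be read between them. No evidence shown bears on this result. The compounds shown leave open whether 3-methylphenyl in place of pyrimidin-5-yl changes the response at all.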